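The compounds below may be only part of what the source reports. "The series", "measured", "known", "first", "only" and "open" are said of these compounds alone.

- compound 1 `CCCOc1c(-c2cc(OC)c(OC)c(OC)c2)oc2ccccc2c1=O`: 11800 nM
- compound 2 `CCCCOc1c(-c2cc(OC)c(OC)c(OC)c2)oc2ccccc2c1=O`: 12800 nM
- compound 3 `CCCC(C)Oc1c(-c2cc(OC)c(OC)c(OC)c2)oc2ccccc2c1=O`: 49300 nM

In a functional assay on PC-3 cells (Homo sapiens) for antiproliferative activity, read by WST assay, with a stated time of 3 days (on this read-out higher numbers stand for weaker inhibition and lower numbers for stronger inhibition), compound 3 gives the highest number of the three, and its steps to both others lie beyond the scatter. Compound 4 `CCN(CC)CCCCCOc1c(-c2cc(OC)c(OC)c(OC)c2)oc2ccccc2c1=O` keeps the shared core but carries 5-(diethylamino)pentyl in place of 1-methylbutyl on an oxygen on an aromatic ring.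

Among the compounds with values here, three measured steps bear on this change. Two are modest, a 4.2-fold higher number from compound 1 to compound 3 (0.62 log units; beyond the scatter) and a 3.9-fold higher number from compound 2 to compound 3 (0.59 log units; beyond the scatter), and both lead to compound 3. The third, a 1.1-fold higher number from compound 1 to compound 2 (0.04 log units; within the scatter), shows no real difference. Compound 4 lacks the methyl that compound 3 carries on the chain carbon bound to the oxygen, so a step to a lower number is expected, of at least modest size. Within the data shown here, no measured compound contains a nitrogen, so the diethylamino end has no measured guide and the range must stay wide. The estimated step is a 6.2-fold lower number from compound 3 to compound 4 (0.79 log units; beyond the scatter). For compound 4 the expected value is 8000 nM, with an estimated range from 1500 nM to 30000 nM.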

Compound 4, half-maximal inhibitory concentration: 6600 nM
Estimate against measurement, compound 4: 1.2-fold (0.08 log units) above, within the range that was stated.
By their numbers in this assay, from the lowest: compounds 4, 1 and 2 (each within the scatter of the next); then compound 3.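

In this assay, within the data shown here, the position on the oxygen on an aromatic ring accepts a chain carrying a nitrogen, which none of the earlier compounds had: 5-(diethylamino)pentyl in place of 1-methylbutyl gives a 7.5-fold lower number from compound 3 to compound 4 (0.87 log units; beyond the scatter). Against the two unbranched chains, the same end group makes no real difference, with a 1.9-fold lower number from compound 2 to compound 4 (0.29 log units; within the scatter) and a 1.8-fold lower number from compound 1 to compound 4 (0.25 log units; within the scatter), so among these four compounds only compound 3, with its 1-methylbutyl group, stands apart. Nothing measured here gives a cause for these steps.

On these data alone, it remains open how a plain pentyl chain would compare, and that comparison would separate the effect of chain length from that of the diethylamino end. Also open, as far as these compounds go, is how a shorter chain ending in diethylamino, or a pentyl chain ending in dimethylamino or morpholine, would read in this assay.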